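The source may report more compounds than this note shows. Statements on the series, on what has been measured and on what is new or still open speak of the compounds shown alone.

Measured so far in an assay on HEK-293T cells for inhibition of diacylglycerol lipase-alpha (Homo sapiens), read by colorimetric assay; a higher number here means a weaker inhibitor, a lower number a stronger inhibitor:
Compound 1, `O=C(CCCCCCc1ccccc1)c1nc(Cl)co1`, gives 2400 nM.
Compound 2, `Cc1coc(C(=O)CCCCCCc2ccccc2)n1`, gives > 10000 nM, a limit of the assay rather than a number.
Compound 3, `CS(=O)(=O)c1cnc(C(=O)CCCCCCc2ccccc2)o1`, gives > 10000 nM, likewise a limit and not a number.

Compound 3 therefore stands at the limit of > 10000 nM in this assay, at which 2 of the 3 values shown sit, and only compound 1 gives a true number in this assay. Compound 4, `CSc1cnc(C(=O)CCCCCCc2ccccc2)o1`, differs from compound 3 by methylsulfanyl in place of methylsulfonyl on an aromatic carbon. Within the data shown here, no measured step changes this group; the single measured step, an at least 4.1-fold higher number from compound 1 to compound 2 (0.61 log units; beyond the scatter), concerns a different substituent and bears only loosely on it, showing that exchanges at this ring can move the number beyond the scatter. Starting from a limit, the step can only be bounded from one side. Compound 4 is expected at about 8000 nM, within 1500 nM to 30000 nM. The expected step for compound 4 is thus an at least 1.2-fold lower number from compound 3 to compound 4 (0.09 log units; that floor lies within the scatter), with a real chance that only a limit is again reported.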

Compound 4, half-maximal inhibitory concentration: > 10000 nM
Compound 4: no number, only a limit; the forecaster's own chance of this, stated with the estimate: 50%; middle value at least 1.2-fold (0.09 log units) from the limit.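

In this assay compound 4 gives > 10000 nM, a limit of the assay, so neither methylsulfanyl nor methylsulfonyl at this position yields a true number. Among these compounds, the steps to compound 4 from compound 3 and from compound 2 cannot be read; the one readable step is an at least 4.1-fold higher number from compound 1 to compound 4 (0.61 log units; beyond the scatter). Only compound 1 keeps a true number, and the rest of the series sits at one value: the limit of > 10000 nM in this assay, at which 3 of the 4 values shown sit.

From the compounds shown here alone, how far compound 3 and compound 4 lie from each other remains unknown. Going by these compounds, whether an amine or a carboxylic acid on this carbon would give a true number also stays open.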